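This account rests on a few compounds, and the source may have more. Where it says the series, first, only, none or still open, it means among the compounds named here.

Measured in an ADME assay on HeLa cells (Homo sapiens) for cytotoxicity, read by ATP content, with a stated time of 3 days; a higher number here means that more compound is tolerated, a lower number that less compound is tolerated:
compound 1 `CS(=O)(=O)CCCn1c(Cn2c(=O)n(C3CC3)c3ccncc32)cc2cc(Cl)ccc21`: > 50000 nM (a limit)
compound 2 `CS(=O)(=O)CCCn1c(Cn2c(=O)n(C3CN(S(C)(=O)=O)C3)c3ccncc32)cc2cc(Cl)ccc21`: > 50000 nM (a limit)
compound 3 `O=c1n(Cc2cc3cc(Cl)ccc3n2CCCCO)c2cnccc2n1C1CC1`: > 50000 nM (a limit)

In this assay compound 1 gives > 50000 nM, which is a limit of the assay. Compound 2 gives > 50000 nM, also a limit. Compound 3 gives > 50000 nM, again a limit. Compound 2 thus stands at the assay limit, where every value shown sits (the limit of > 50000 nM in this assay, at which 3 of the 3 values shown sit). The step that the two limits leave unreadable from compound 1 to compound 2 changes the group on the aromatic nitrogen, and a step that the two limits leave unreadable from compound 1 to compound 3 changes the chain; neither can be sized. Compound 4 `CC(C)(C)n1c(=O)n(Cc2cc3cc(Cl)ccc3n2CCCS(C)(=O)=O)c2cnccc21` differs from compound 2 by tert-butyl in place of 1-(methylsulfonyl)azetidin-3-yl on an aromatic nitrogen. Within the data shown here, no measured step gives a readable size for a change of this kind, so no direction in this assay can be drawn. Compound 4 is expected at 60000 nM, between 25000 nM and 150000 nM. The expected step that the limit leaves unreadable from compound 2 to compound 4 is none beyond the scatter.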

Compound 4, half-maximal cytotoxic concentration: > 50000 nM
Compound 4 was reported as a limit; the forecaster's own chance of this, stated with the estimate: 80%; the middle value lies beyond the limit too.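

No step from compound 1 or compound 2 to compound 4 can be read in this assay, because the values give only a shared limit: the limit of > 50000 nM in this assay, at which 4 of the 4 values shown sit.

The compounds shown leave open at what concentration any of them turns cytotoxic, and whether the group on the aromatic nitrogen or the chain shifts that concentration.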